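Thromboxane Synthase Inhibitors: An Aryl Ether Swap

The source may report more compounds than this note shows. Statements on the series, on what has been measured and on what is new or still open speak of the compounds shown alone.

Compound 1 `CSc1ccc(OC(C)(C)C2OCC(C/C=C\CCC(=O)O)C(c3cccnc3)O2)c([N+](=O)[O-])c1`: 22 nM
Compound 2 `COc1ccc(OC(C)(C)C2OCC(C/C=C\CCC(=O)O)C(c3cccnc3)O2)cc1`: 41 nM
Compound 3 `CC(C)(Oc1ccc(F)cc1)C1OCC(C/C=C\CCC(=O)O)C(c2cccnc2)O1`: 51 nM

In an assay for inhibition of Thromboxane-A synthase (Homo sapiens), using microsomes (on this read-out higher numbers stand for weaker inhibition and lower numbers for stronger inhibition), compound 3 gives the highest of the three numbers; against compound 2 it sits within the scatter, while a 2.3-fold higher number from compound 1 to compound 3 (0.37 log units; beyond the scatter). Compound 4 `CSc1ccccc1OC(C)(C)C1OCC(C/C=C\CCC(=O)O)C(c2cccnc2)O1` carries 2-(methylsulfanyl)phenyl in place of 4-fluorophenyl on an oxygen on a saturated carbon. Among the compounds with values here, no measured step matches this change exactly. The nearest guide is a 2.3-fold higher number from compound 1 to compound 3 (0.37 log units; beyond the scatter), where the aryl group of compound 1 also holds a methylsulfanyl group; a 1.9-fold higher number from compound 1 to compound 2 (0.27 log units; within the scatter) shows that removing it and the nitro group together changes little. A modest move back toward the number of compound 1 is therefore expected, with a 1.7-fold lower number from compound 3 to compound 4 (0.23 log units; within the scatter). Compound 4 is estimated at 30 nM, within a range from 12 nM to 75 nM.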

Compound 4, half-maximal inhibitory concentration: 36 nM
The estimate for compound 4 lay 1.2-fold (0.08 log units) below the measured number; measured number inside the range.
By their numbers in this assay, from the lowest: compounds 1, 4, 2 and 3 (each within the scatter of the next, the first and the last beyond it).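

Swapping the aryl group on this oxygen barely moves the number in this assay: the change from 4-fluorophenyl to 2-(methylsulfanyl)phenyl stays within the scatter (a 1.4-fold lower number from compound 3 to compound 4 (0.15 log units; within the scatter)), as does the change from 4-methoxyphenyl (a 1.1-fold lower number from compound 2 to compound 4 (0.06 log units; within the scatter)). The aryl group of compound 4 lacks the nitro group of compound 1, yet this step also stays within the scatter (a 1.6-fold higher number from compound 1 to compound 4 (0.21 log units; within the scatter)). No available evidence accounts for these results. As far as these compounds go, whether an amine or a hydroxyl group on this aryl ring would carry the number beyond the scatter remains open.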